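This account rests on a few compounds, and the source may have more. Where it says the series, first, only, none or still open, it means among the compounds named here.

Measured compounds:
Compound 1 `CC1(C(=O)NS(=O)(=O)Cc2ccc(F)cc2F)CCN(c2nc3c(cc2C#N)C(=O)OC3)CC1` — in a functional assay (Platelet, plasma) for inhibition, with Homo sapiens as the target (on this read-out higher numbers stand for weaker inhibition and lower numbers for stronger inhibition), compound 1 gives 8760 nM.
Compound 2 `N#Cc1cc2c(nc1N1CCC(F)(C(=O)NS(=O)(=O)c3ccc(Cl)s3)CC1)COC2=O` — in this assay compound 2 gives 37100 nM.
Compound 3 `N#Cc1cc2c(nc1N1CCC(F)(C(=O)NS(=O)(=O)Cc3ccccc3)CC1)COC2=O` — in this assay compound 3 gives 1210 nM.

Compound 2 stands highest of the three numbers: compound 1 is nearest to it and compound 3 furthest, and both of those gaps lie beyond the scatter. For the measured compounds named here, the one measured step, a 31-fold lower number from compound 2 to compound 3 (1.49 log units; beyond the scatter), concerns the group on the sulfonyl sulfur, not the saturated ring carbon.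

The unmeasured compound 4 `CC1(C(=O)NS(=O)(=O)c2ccc(Cl)s2)CCN(c2nc3c(cc2C#N)C(=O)OC3)CC1` differs from compound 2 in one place: methyl in place of fluoro on a saturated ring carbon. Going by the values given here, no measured step concerns this change on its own. Compound 1 and compound 3, which carry methyl and fluoro at that carbon, differ from each other in a second place as well, so their two values cannot be read as the effect of this change alone. The change is expected to give at most a small step, a 1.2-fold lower number from compound 2 to compound 4 (0.09 log units; within the scatter), in this assay, with no confident direction. Compound 4 is therefore estimated at 30000 nM, between 8000 nM and 110000 nM.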

Compound 4, half-maximal inhibitory concentration: 1640 nM
For compound 4 the middle estimate is 18-fold (1.26 log units) above the measured one; the measured number lies below the stated range.
By their numbers in this assay, from the lowest: compounds 3 and 4 (each within the scatter of the next); then compound 1; then compound 2.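

In this assay, the saturated ring carbon proves highly sensitive to this exchange of one heavy atom for another: methyl in place of fluoro gives a 23-fold lower number from compound 2 to compound 4 (1.35 log units; beyond the scatter). With methyl held at that carbon, 5-chlorothiophen-2-yl in place of 2,4-difluorobenzyl on the sulfonyl sulfur gives a 5.3-fold lower number from compound 1 to compound 4 (0.73 log units; beyond the scatter), so this thiophene group is not a poor choice in every setting, even though compound 2 has the highest number of the set. Nothing shown here accounts for the size of the methyl step.

The compounds shown leave open how a hydroxyl or an ethyl on that saturated ring carbon would read. They also leave open how unsubstituted benzyl on the sulfonyl sulfur would read with methyl at that carbon, which would show whether the methyl gain carries over to a second sulfonyl group.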